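The compounds below may be only part of what the source reports. "The series", "measured", "known", "first", "only" and "open" are said of these compounds alone.

Two compounds of a shared core were measured in a functional assay on SW-620 cells (Homo sapiens) for inhibition, read by sulforhodamine B assay, with a stated time of 48 h; on this read-out lower numbers stand for stronger inhibition of growth and higher numbers for weaker inhibition of growth. Among the measured compounds shown here, compound 1 `COc1ccc(-c2[nH]c3ccccc3c2/C=C(\C#N)S(=O)(=O)c2ccccc2)cc1` gives 506 nM there, and compound 2 `COc1ccc(-c2[nH]c3ccc(OC)cc3c2/C=C(\C#N)S(=O)(=O)c2ccccc2)cc1` gives 540 nM; the only step between them, a 1.1-fold higher number from compound 1 to compound 2 (0.03 log units; within the scatter), leaves compound 2 standing close to its sole neighbour. Compound 3 `COc1ccc2[nH]c(-c3ccccc3)c(/C=C(\C#N)S(=O)(=O)c3ccccc3)c2c1` differs from compound 2 by hydrogen in place of methoxy on an aromatic carbon, so that a 4-methoxyphenyl becomes a phenyl. For the measured compounds named here, no measured step touches that ring, and the one step known changes little, so no shift beyond the scatter is expected, a 1.1-fold higher number from compound 2 to compound 3 (0.05 log units; within the scatter). Compound 3 is estimated at 600 nM, between 300 nM and 1200 nM.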

Compound 3, concentration for 50% growth inhibition: 4000 nM
Beside the measured number, compound 3's estimate is 6.7-fold (0.82 log units) below it; measured number outside the range, above it.
By their numbers in this assay, from the lowest: compounds 1 and 2 (each within the scatter of the next); then compound 3.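

In this assay, the change from 4-methoxyphenyl to phenyl gives a 7.4-fold higher number from compound 2 to compound 3 (0.87 log units; beyond the scatter), so growth inhibition in this series does depend on the methoxy at this position, para to a large group. Among the compounds shown here, the only earlier step, a 1.1-fold higher number from compound 1 to compound 2 (0.03 log units; within the scatter), concerned the other methoxy and showed no such dependence. Nothing measured here accounts for the difference. Still open, as far as these compounds go, is whether an ethoxy, a hydroxy, a fluorine or an amine at this position would keep the number of compound 2, and whether the other methoxy matters once the 4-methoxyphenyl is gone.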